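Amide substituent swap on the shared core: stability notes

A few compounds are considered here, and "the series" means these few. Any claim that something is new, unique, unknown or untested is made for them only; others in the source may bear on it.

The series shares the core of compound 1 `Cn1ccc2ccc(-c3cc(Nc4ccccc4S(=O)(=O)Nc4cncnc4)cc4nccnc34)cc21`, which in an ADME assay on microsomes from liver (Mus musculus, strain CD-1) for metabolic stability, read by LC-MS, tested at 2 uM (on this read-out higher numbers stand for a longer-lived compound and lower numbers for a shorter-lived compound), gives compound 1 a reading of 0.683 h. Compound 2 `CN1CCC(NC(=O)c2ccncc2Nc2cc(-c3ccc4ccn(C)c4c3)c3nccnc3c2)CC1` carries an amide in place of the sulfonamide side. In this assay compound 2 gives > 1 h, which is a limit of the assay and not a number. Within the data shown here, compound 2 therefore stands at the limit, the one reading of the two that does so (the limit of > 1 h in this assay, at which 1 of the 2 values shown sits).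

Compound 3 `CC(=O)N1CC(CNC(=O)c2ccncc2Nc2cc(-c3ccc4ccn(C)c4c3)c3nccnc3c2)C1` differs from compound 2 in one place: (1-acetylazetidin-3-yl)methyl in place of 1-methylpiperidin-4-yl on an amide-type nitrogen. Among the measured compounds shown here, no pair of measured compounds differing in one place is available, so no measured step sets a scale for this change. The expectation in this assay is for a step from compound 2 to compound 3 no larger than the usual scatter, in either direction, with the limit reading of compound 2 leaving the direction open. Compound 3 is therefore expected to give about 1 h, estimated to lie between 0.4 h and 2.5 h. The expected shift is a number no higher from compound 2 to compound 3 (the limit leaves the size open).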

Compound 3, half-life: > 1 h
Compound 3: only a limit was reported; the forecaster's own chance of this, stated with the estimate: 40%; the middle value sits exactly at the limit.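

In this assay compound 2 and compound 3 both report only a limit, so no step between them can be read: the limit of > 1 h in this assay, at which 2 of the 3 values shown sit.

The compounds shown leave open how far either half-life lies beyond the limit, and whether (1-acetylazetidin-3-yl)methyl in place of 1-methylpiperidin-4-yl on an amide-type nitrogen changes it in either direction.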